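Swapping the Aryl Group: What to Expect for Compound 4

This account rests on a few compounds, and the source may have more. Where it says the series, first, only, none or still open, it means among the compounds named here.

Measured in a functional assay on MCF7 cells (Homo sapiens) for antiproliferative activity, read by MTT assay, with a stated time of 72 h; on this read-out lower numbers stand for stronger inhibition and higher numbers for weaker inhibition:
- compound 1 `COc1cc(-n2cnc3ccc(-c4ccc(C)cc4F)cc32)cc(OC)c1OC` gives 56 nM
- compound 2 `COc1cc(-n2cnc3ccc(-c4cccc(O)c4)cc32)cc(OC)c1OC` gives 350 nM
- compound 3 `COc1cc(-n2cnc3ccc(-c4cccc(F)c4)cc32)cc(OC)c1OC` gives 2350 nM

Compound 1 stands lowest of the three, so it is the strongest inhibitor in this set. Its nearest neighbour is compound 2, reached by a 6.3-fold higher number from compound 1 to compound 2 (0.80 log units; beyond the scatter). Its furthest is compound 3, reached by a 42-fold higher number from compound 1 to compound 3 (1.62 log units; beyond the scatter). Between those two, the step of a 6.7-fold higher number from compound 2 to compound 3 (0.83 log units; beyond the scatter) shows that hydroxy and fluoro on the same ring position give clearly different results.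

Compound 4 `COc1cc(-n2cnc3ccc(-c4ccc(Cl)cc4Cl)cc32)cc(OC)c1OC` differs from compound 1 in one place: 2,4-dichlorophenyl in place of 2-fluoro-4-methylphenyl on an aromatic carbon. The two measured steps out of compound 1 both exchange this same aryl group, and both gave higher numbers, one modest and one large. Neither of them, however, puts chlorine on the ring, and both remove the substitution pattern that compound 1 carries, whereas compound 4 keeps a 2,4-pattern with different atoms. The evidence therefore points to a step of modest size at most, more likely upward than downward, and a result within the scatter cannot be ruled out. Compound 4 is expected to show a step of a 2.7-fold higher number from compound 1 to compound 4 (0.43 log units; beyond the scatter), giving an estimate of 150 nM with a range from 40 nM to 600 nM.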

Compound 4, half-maximal inhibitory concentration: 5420 nM
Beside the measured number, compound 4's estimate is 36-fold (1.56 log units) below it, outside the stated range (above it).
By their numbers in this assay, from the lowest: compound 1; then compound 2; then compound 3; then compound 4.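

Two aryl groups with the same heavy-atom count, no hydrogen-bond donors or acceptors and no net charge still give very different results at this position, with a 97-fold higher number from compound 1 to compound 4 (1.99 log units; beyond the scatter) as the step, so those counts alone do not predict what happens here. The substitution pattern alone does not carry the low number either: the 2,4-dichlorophenyl group ends up the weakest of the four, with a 2.3-fold higher number from compound 3 to compound 4 (0.36 log units; beyond the scatter) as its step from the 3-fluorophenyl group and a 15-fold higher number from compound 2 to compound 4 (1.19 log units; beyond the scatter) as its step from the 3-hydroxyphenyl group. No measurement available here explains why this exchange costs so much.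

In going from compound 1 to compound 4, the fluoro and the methyl are replaced together, so the compounds shown cannot tell whether one swap or both account for the loss. Also open, as far as these compounds go, is how this position would respond to a ring bearing a methoxy group, an amine or a carboxylic acid, and whether any of these would come close to compound 1.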